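The source may report more compounds than this note shows. Statements on the series, on what has been measured and on what is new or still open speak of the compounds shown alone.

Measured so far:
compound 2 `CCCCCCCCn1nnc(C(C(=O)Nc2c(OC)cc(OC)cc2OC)c2ccccc2)n1` in an assay on liver for inhibition of sterol O-acyltransferase 1 (Rattus norvegicus), using microsomes; a lower number here means a stronger inhibitor, a higher number a weaker inhibitor: 270 nM
compound 1 `CCCCCCCCCCCCn1nnc(C(C(=O)Nc2c(OC)cc(OC)cc2OC)c2ccccn2)n1` in this assay: 590 nM

Compound 2 stands at the lowest of the two numbers; compound 1 sits at a higher number, a gap beyond the scatter. Compound 1 and compound 2 differ in more than one place, so no single step can be read from them.

Compound 3 `C=CCCCCCCCCCn1nnc(C(C(=O)Nc2c(OC)cc(OC)cc2OC)c2ccccc2)n1` differs from compound 2 by allyl in place of hydrogen on a saturated chain carbon, eight bonds along the chain from an aromatic nitrogen. For the measured compounds named here, no comparable step between measured compounds is known. A small move is expected, in either direction, with the step from compound 2 to compound 3 estimated as a 1.1-fold higher number from compound 2 to compound 3 (0.05 log units; within the scatter). Compound 3 is expected at 300 nM, range 120 nM to 750 nM.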

Compound 3, half-maximal inhibitory concentration: 54 nM
Compound 3: middle estimate off by 5.6-fold (0.74 log units), on the high side; measured number outside the range, below it.
By their numbers in this assay, from the lowest: compound 3; then compound 2; then compound 1.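

In this assay, the far end of the chain on the aromatic nitrogen proves responsive: allyl in place of hydrogen on a saturated chain carbon, eight bonds along the chain from an aromatic nitrogen, gives a 5.0-fold lower number from compound 2 to compound 3 (0.70 log units; beyond the scatter). This one change both extends the chain and brings in a double bond, so the step does not separate the two. No available measurement bears on the reason for this step.

On these data alone, whether a saturated undecyl chain would match compound 3 remains open. So does the outcome with a longer chain or an amine on the chain.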